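A few compounds are considered here, and "the series" means these few. Any claim that something is new, unique, unknown or untested is made for them only; others in the source may bear on it.

Measured in a functional assay on PANC-1 cells (Homo sapiens) for inhibition, read by MTT assay, with a stated time of 24 h; on this read-out higher numbers stand for weaker inhibition and lower numbers for stronger inhibition:
- compound 1 `CC1(C)[C@H]2CC[C@]1(C)N(Cc1cn(-c3ccc(F)cc3)nn1)C(=O)C2`: 110 nM
- compound 2 `Cc1ccccc1-n1cc(CN2C(=O)C[C@@H]3CC[C@@]2(C)C3(C)C)nn1`: 250 nM
- compound 3 `COc1cccc(-n2cc(CN3C(=O)C[C@@H]4CC[C@@]3(C)C4(C)C)nn2)c1`: 860 nM

Of the three, compound 3 gives the highest number, 860 nM, and so the weakest inhibition. The next structure is compound 4 `Cc1cccc(-n2cc(CN3C(=O)C[C@@H]4CC[C@@]3(C)C4(C)C)nn2)c1`, with methyl in place of methoxy on an aromatic carbon.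

Going by the values given here, no measured step makes this exact swap. The closest is a 3.4-fold higher number from compound 2 to compound 3 (0.54 log units; beyond the scatter), with 3-methoxyphenyl in place of 2-methylphenyl, although that step also moves the group. The other steps are a 2.3-fold higher number from compound 1 to compound 2 (0.36 log units; beyond the scatter) and a 7.8-fold higher number from compound 1 to compound 3 (0.89 log units; beyond the scatter). All three are modest and beyond the scatter, so aryl substitution does shift this series in this assay.

Among the compounds with values here, compound 2, the only measured compound with a methyl on the phenyl, gives 250 nM, so a modest step toward a lower number is expected, though on thin evidence.

The expected step is a 2.0-fold lower number from compound 3 to compound 4 (0.31 log units; beyond the scatter). For compound 4 the estimated value is 420 nM, with an expected range of 160 nM to 1000 nM.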

Compound 4, half-maximal inhibitory concentration: 240 nM
Beside the measured number, compound 4's estimate is 1.8-fold (0.24 log units) above it, within the range that was stated.
By their numbers in this assay, from the lowest: compound 1; then compounds 4 and 2 (each within the scatter of the next); then compound 3.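

Going by these compounds alone, with the place on the ring held fixed, methyl in place of methoxy in this assay gives a 3.6-fold lower number from compound 3 to compound 4 (0.55 log units; beyond the scatter), a step the earlier compounds could only suggest through a swap that also moved the group. Moving the methyl from 2-methylphenyl to 3-methylphenyl gives a 1.0-fold lower number from compound 2 to compound 4 (0.02 log units; within the scatter), which is within the scatter, while 4-fluorophenyl keeps an edge over 3-methylphenyl, with a 2.2-fold higher number from compound 1 to compound 4 (0.34 log units; beyond the scatter). Nothing available bears on the reason for any of these steps.

Still open, going by these compounds, is how an amine, a carboxylic acid or a longer chain on the same aromatic carbon would compare with the methyl of compound 4. Also open, on these data alone, is where an unsubstituted phenyl would fall relative to compound 1 and compound 4.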